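A few compounds are considered here, and "the series" means these few. Any claim that something is new, unique, unknown or untested is made for them only; others in the source may bear on it.

The compounds measured in a functional assay on PC-3 cells (Homo sapiens) for cytotoxicity, read by MTT assay, with a stated time of 72 h (on this read-out higher numbers stand for weaker inhibition and lower numbers for stronger inhibition), so far:

Compound 1 `COc1ccc(-n2ccc(=O)c(C(=O)Nc3ccc(Oc4ccnc5c4ccn5C)cc3)n2)cc1` gives > 60000 nM, which is a limit of this assay and not a number.
Compound 2 `Cn1ccc2c(Oc3ccc(NC(=O)c4nn(-c5ccccc5)ccc4=O)cc3F)ccnc21` gives > 60000 nM, again a limit of this assay.
Compound 3 `Cc1cc(=O)n(-c2ccc(F)cc2)nc1C(=O)Nc1ccc(Oc2ncnc3[nH]ccc23)cc1` gives > 60000 nM, also a limit of this assay.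

Where compound 3 stands is therefore only a boundary: it sits at the limit of > 60000 nM in this assay, at which 3 of the 3 values shown sit, together with the two other compounds, and no value separates any of the three from the others. Among the measured compounds shown here, no step between measured compounds can be read from these numbers, and nothing in them shows which parts of the shared core of compound 3 matter for the read-out.

Compound 4 `Cc1cc(=O)n(-c2ccc(Br)cc2F)nc1C(=O)Nc1ccc(Oc2ncnc3[nH]ccc23)cc1` is the next compound to go into this assay. The change from compound 3 is 4-bromo-2-fluorophenyl in place of 4-fluorophenyl on an aromatic nitrogen; the 4-bromo-2-fluorophenyl enters next to the ring nitrogen, ortho to a group of one heavy atom, meta to a large group and para to a methyl group.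

Since compound 3 shows only a limit, no step beyond the scatter can be expected in either direction for compound 4, and the most likely outcome is a further limit. Compound 4 is estimated at 60000 nM, with a range from 15000 nM to 200000 nM, which would mean a step of a number no higher from compound 3 to compound 4 (the limit leaves the size open).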

Compound 4, half-maximal inhibitory concentration: 2730 nM
Beside the measured number, compound 4's estimate is 22-fold (1.34 log units) above it; the measured number lies below the stated range.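

In this assay compound 3 gives > 60000 nM which is a limit of this assay and not a number. The group on the aromatic nitrogen is thus the first place in this series where a change moves the read-out off that limit: 4-bromo-2-fluorophenyl in place of 4-fluorophenyl gives an at least 21-fold lower number from compound 3 to compound 4 (1.34 log units; beyond the scatter) and shows that this position can affect the read-out on the core shared by compound 3 and compound 4. Compound 4 is also the only compound shown with a measured number, and the others remain at the boundary: the limit of > 60000 nM in this assay, at which 3 of the 4 values shown sit.

The change puts in a bromine and a second fluorine together, so these compounds cannot say which of the two accounts for the step, or whether both are needed; a 4-bromophenyl or a 2-fluorophenyl group would separate them, and a 4-chloro-2-fluorophenyl group would test whether bromine itself matters. Compound 1 and compound 2 differ from compound 4 in more than one place, so no steps can be read to them, and the values shown give no cause for the step.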